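The source may hold more compounds than are shown below. What is called first, only, known or untested is meant among the compounds shown, and "the series" means these compounds.

For the measured compounds named here, compound 1 `CC(=O)OCC[S+]([O-])CC1CN(C)CCC1c1ccc(Cl)cc1` gives 9 nM in an assay on isolated protein for inhibition of sodium-dependent dopamine transporter (Rattus norvegicus), read by radioligand binding (a lower number here means a stronger inhibitor, a higher number a weaker inhibitor), the lowest of the two numbers measured so far. Going by the values given here, compound 2 `CN1CCC(c2ccc(Cl)cc2)C(CSCCOC(=O)c2ccccc2)C1` gives 68 nM in this assay, a gap from compound 1 that lies beyond the scatter; no single-point step links these two, so only their two values are noted. Compound 3 `Cc1noc(C[S+]([O-])CC2CN(C)CCC2c2ccc(Cl)cc2)n1`, not yet measured, differs from compound 1 by 3-methyl-1,2,4-oxadiazol-5-yl in place of acetoxymethyl on a saturated chain carbon bound to a sulfur. Without a measured step of this kind, the change from compound 1 to compound 3 is expected to be small, if anything toward a higher number, a 1.7-fold higher number from compound 1 to compound 3 (0.22 log units; within the scatter). For compound 3 the estimate in this assay is 15 nM, within 4 nM to 60 nM.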

Compound 3, inhibition constant: 1650 nM
Compound 3: middle estimate off by 110-fold (2.04 log units), on the low side; measured number outside the range, above it.
By their numbers in this assay, from the lowest: compound 1; then compound 2; then compound 3.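

On a saturated chain carbon bound to a sulfur, the group is not freely exchangeable in this assay: 3-methyl-1,2,4-oxadiazol-5-yl in place of acetoxymethyl gives a 180-fold higher number from compound 1 to compound 3 (2.26 log units; beyond the scatter) and weakens inhibition. For the compounds shown here, this is the only single-place step, so it shows that this position can respond strongly but fixes no trend. Nothing available here explains the size of this step.

Still open, on these data alone, is whether the loss follows from the five-membered aromatic ring or from the removal of the acetoxy ester. A methyl ester, a carboxylic acid or an amine at this place could separate these readings.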